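Amide in place of sulfonamide on the shared core

A few compounds are considered here, and "the series" means these few. Any claim that something is new, unique, unknown or untested is made for them only; others in the source may bear on it.

Measured compounds:
- compound 1 `CCCN(CCC)S(=O)(=O)c1ccc(S(=O)(=O)N2CCC[C@@H](C(=O)OCC)C2)cc1`: 600 nM
- compound 2 `CCOC(=O)[C@@H]1CCCN(S(=O)(=O)c2ccc(S(=O)(=O)N3CCCCC3)cc2)C1`: 1000 nM
- compound 3 `CCOC(=O)[C@@H]1CCCN(S(=O)(=O)c2ccc(S(=O)(=O)N(C)C)cc2)C1`: 300 nM

All three numbers come from a functional assay on MIA PaCa-2 cells (Homo sapiens) for inhibition, read by MTT assay, with a stated time of 3 days; a lower number here means a stronger inhibitor, a higher number a weaker inhibitor. Compound 3 has the lowest of the three numbers. Its nearest neighbour is compound 1, and that gap, a 2.0-fold lower number from compound 1 to compound 3 (0.30 log units; within the scatter), is within the scatter. The furthest is compound 2, and a 3.3-fold lower number from compound 2 to compound 3 (0.52 log units; beyond the scatter) is beyond the scatter, a modest step. The remaining pair, a 1.7-fold higher number from compound 1 to compound 2 (0.22 log units; within the scatter), is within the scatter, so the three amines on the sulfonyl sulfur span only a small range.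

Compound 4 `CCOC(=O)[C@@H]1CCCN(S(=O)(=O)c2ccc(C(=O)N(CC)CC)cc2)C1` is not yet measured. It differs from compound 3 by diethylcarbamoyl in place of dimethylsulfamoyl on an aromatic carbon. Within the data shown here, none of the measured steps bears directly on this change: each of them varies only the amine on a sulfonyl sulfur and keeps the sulfonyl itself, whereas here the sulfonyl is replaced by a carbonyl and the dimethylamino by a diethylamino. The three measured steps were small, from within the scatter to modest, which argues for a step of similar size in this assay, but its direction cannot be read from the data.

Compound 4 is therefore expected near 500 nM, with a range of 150 nM to 2000 nM. That estimate corresponds to a 1.7-fold higher number from compound 3 to compound 4 (0.22 log units; within the scatter).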

Compound 4, half-maximal inhibitory concentration: 100 nM
For compound 4 the middle estimate is 5.0-fold (0.70 log units) above the measured one; the measured number lies below the stated range.
By their numbers in this assay, from the lowest: compound 4; then compounds 3, 1 and 2 (each within the scatter of the next, the first and the last beyond it).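

Working notes on the series: at this position, on an aromatic carbon para to a large group, the sulfonyl is not required for activity in this assay, as diethylcarbamoyl in place of dimethylsulfamoyl gives a step beyond the scatter (a 3.0-fold lower number from compound 3 to compound 4 (0.48 log units; beyond the scatter)). Compound 4 now has the lowest number of the four, with steps beyond the scatter from the other two sulfonamides as well (a 6.0-fold lower number from compound 1 to compound 4 (0.78 log units; beyond the scatter); a 10-fold lower number from compound 2 to compound 4 (1.00 log units; beyond the scatter)), the latter being the largest step in the series and larger than any step seen by varying only the amine on the sulfonyl sulfur. No supporting data are available to explain this difference.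

On these data alone, the step from compound 3 to compound 4 changes the sulfonyl to a carbonyl and the dimethylamino to a diethylamino at once, so the share of each remains open, and a dimethylcarbamoyl or a diethylsulfamoyl group at this position would separate them. As far as these compounds go, the ethyl ester is constant across all four compounds, so how a carboxylic acid or a primary amide at that place would read alongside the diethylcarbamoyl group is also open.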